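From Chloro to Fluoro: Three Measurements and One Estimate

The source may hold more compounds than are shown below. What is called first, only, known or untested is meant among the compounds shown, and "the series" means these compounds.

Of the compounds shown here, three of one series have been measured in a functional assay on HaCaT cells (Homo sapiens), read by fluorescence and BrdU incorporation, with a stated time of 48 h, tested at 10 uM; on this read-out higher numbers stand for a weaker effect at the one concentration tested and lower numbers for a stronger effect. Compound 1, `COc1cc(OC)c(C(=O)/C=C/c2ccc(Cl)cc2)c(OC)c1`, gives 26% in this assay. Compound 2, `COc1cccc(/C=C/C(=O)c2c(O)cc(OC)cc2OC)c1`, gives 49%, and compound 3, `COc1cc(O)c(C(=O)/C=C/c2ccccc2SC)c(OC)c1`, gives 51%. Compound 1 thus stands lowest of the three numbers, which on this read-out means the strongest effect at the one concentration tested; its gap to compound 2 and its gap to compound 3 both lie beyond the scatter. The numbers of compound 2 and compound 3 lie within the scatter of each other, so nothing separates them.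

The next compound, compound 4, `COc1cc(OC)c(C(=O)/C=C/c2ccc(F)cc2)c(OC)c1`, has not yet been measured. It differs from compound 1 in a single place: fluoro in place of chloro on an aromatic carbon. Among the measured compounds shown here, no pair among the measured compounds isolates this change, so any expectation rests on compound 1 alone. The exchange of one halogen for another at the same place is expected to move the number only moderately, and the step from compound 1 to compound 4 is expected to be a number 14 percentage points higher from compound 1 to compound 4 (beyond the scatter), a rise toward a weaker effect that may or may not exceed the scatter. Compound 4 is therefore estimated at 40%, with a range from 22% to 65%.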

Compound 4, a percentage reported as activity, at one concentration (the size of the read-out at that concentration, not a potency): 20%
For compound 4 the middle estimate is 20 percentage points above the measured one; measured number below the stated range.
By their numbers in this assay, from the lowest: compounds 4 and 1 (each within the scatter of the next); then compounds 2 and 3 (each within the scatter of the next).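

In this assay, fluoro in place of chloro on an aromatic carbon, para to a large group, amounts to a number 6 percentage points lower from compound 1 to compound 4 (within the scatter), so this read-out does not tell the two halogens apart at this position. As the only pair shown that isolates a single change, compound 1 and compound 4 show that the low number of compound 1 does not depend on chloro in particular: the 4-fluorophenyl group serves as well as the 4-chlorophenyl group at the one concentration tested. No measurement at hand bears on what lies behind this result.

As far as these compounds go, whether the effect survives something other than a halogen at this place remains open, and an amine, a methoxy group or a carboxylic acid on the same aromatic carbon would address that question. Compound 2 and compound 3 differ from compound 1 and compound 4 in more than one place, so no step to them can be read, and which of those differences accounts for their higher numbers also remains unsettled.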